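Oxadiazole benzamides on lung carcinoma cells: amide-end change

This account rests on a few compounds, and the source may have more. Where it says the series, first, only, none or still open, it means among the compounds named here.

Measured so far:
compound 1 `Nc1ccccc1NC(=O)c1ccc(CNCc2nc(-c3ccc(C(F)(F)F)cc3)no2)cc1` — 23500 nM
compound 2 `Nc1ccccc1NC(=O)c1ccc(CNCc2nc(-c3ccc(Cl)cc3)no2)cc1` — 8000 nM
compound 3 `Nc1ccccc1NC(=O)c1ccc(CNCc2nc(-c3cccs3)no2)cc1` — 35800 nM

In a functional assay on NCI-H661 cells (Homo sapiens) for inhibition, read by MTT assay, with a stated time of 72 h (on this read-out lower numbers stand for stronger inhibition and higher numbers for weaker inhibition), compound 2 gives the lowest number of the three; the steps of a 2.9-fold lower number from compound 1 to compound 2 (0.47 log units; beyond the scatter) and a 4.5-fold higher number from compound 2 to compound 3 (0.65 log units; beyond the scatter) both lie beyond the scatter, whereas a 1.5-fold higher number from compound 1 to compound 3 (0.18 log units; within the scatter) does not. Compound 4 `O=C(NO)c1ccc(CNCc2nc(-c3ccc(Cl)cc3)no2)cc1` differs from compound 2 by hydroxy in place of 2-aminophenyl on an amide-type nitrogen. None of the measured steps touches this part of the molecule; all three concern only the group on the aromatic carbon of the shared core, so no step shown bears on the present change, and its direction cannot be read from the series. The expectation for compound 4 is therefore loosely held and the range wide. Compound 4 is estimated at 3000 nM (range 400 nM to 20000 nM), that is an expected step of a 2.7-fold lower number from compound 2 to compound 4 (0.43 log units; beyond the scatter).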

Compound 4, half-maximal inhibitory concentration: > 100000 nM
Compound 4 was reported as a limit (the forecaster's own chance of this, stated with the estimate: 5%); at least 33-fold (1.52 log units) between middle value and limit.
By their numbers in this assay, from the lowest: compound 2; then compounds 1 and 3 (each within the scatter of the next). At a limit, above all of these: compound 4.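

At the amide-type nitrogen, in this assay, hydroxy in place of 2-aminophenyl gives an at least 12-fold higher number from compound 2 to compound 4 (1.09 log units; beyond the scatter), a larger step than any among the aromatic-carbon changes in compounds 1, 2 and 3. Compound 4 is reported only as a limit, > 100000 nM, so this step has a floor rather than a measured size: the limit of > 100000 nM in this assay, at which 1 of the 4 values shown sits.

On these data alone, whether the ring or its amino group matters remains open; a plain phenyl on the same nitrogen would separate the two. Also open, as far as these compounds go, is whether hydroxy gives the same result alongside 4-(trifluoromethyl)phenyl or thiophen-2-yl.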